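Working notes on the step to compound 4

The source may report more compounds than this note shows. Statements on the series, on what has been measured and on what is new or still open speak of the compounds shown alone.

Values from an ADME assay on a cell-free system (plasma, Mus musculus) for metabolic stability, tested at 1 uM (on this read-out higher numbers stand for a longer-lived compound and lower numbers for a shorter-lived compound), as follows
- compound 1 `C=CC(=O)NCC1CCN(S(=O)(=O)c2ccc(NC(=O)OCc3ccccc3)cc2)CC1` gives > 6 h (a limit)
- compound 2 `C=CC(=O)N1CCN(S(=O)(=O)c2ccc(NC(=O)OCc3ccccc3)cc2)CC1` gives > 6 h (a limit)
- compound 3 `C=CC(=O)N[C@@H]1CCCN(S(=O)(=O)c2ccc(NC(=O)OCc3ccccc3)cc2)C1` gives > 6 h (a limit)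

Not yet measured
- compound 4 `C=CC(=O)NC1CN(S(=O)(=O)c2ccc(NC(=O)OCc3ccccc3)cc2)C1`

Compound 2 stands at > 6 h as a limit and not a number. The whole measured set reads the same way, with the limit of > 6 h in this assay, at which 3 of the 3 values shown sit, and no exact half-life among them. Within the data shown here, the groups on the sulfonyl sulfur differ across compounds 1, 2 and 3, yet the three results cannot be told apart, and no step between measured compounds can be read from them.

Going to compound 4, the change is a group of 9 heavy atoms (6 carbon, 2 nitrogen, 1 oxygen; one four-membered non-aromatic ring with 1 hetero atom) in place of a group of 10 heavy atoms (7 carbon, 2 nitrogen, 1 oxygen; one six-membered non-aromatic ring with 2 hetero atoms), on a sulfonyl sulfur and the rest of the structure stays as it is. The 4-(vinylcarbonyl)piperazin-1-yl group leaves, and a group with one four-membered non-aromatic ring enters.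

No step beyond the usual scatter is expected in this assay for this change. That expectation rests on compound 3 at > 6 h as a limit, and the same limit holds for compounds 1 and 2. The expected change is a step that the limit leaves unreadable from compound 2 to compound 4 and is estimated to stay within the scatter. Compound 4 is expected at 8 h with an estimated range of 4 h to 15 h and may well end up as a limit too.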

Compound 4, half-life: > 6 h
Compound 4 ended at the assay's limit (the forecaster's own chance of this, stated with the estimate: 85%); the middle value does not contradict the limit.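

In this assay, compound 4 gives > 6 h, a limit and not a number. Compound 2 also stands at a limit, so no step can be read from compound 2 to compound 4: the limit of > 6 h in this assay, at which 4 of the 4 values shown sit.

The compounds shown leave open what the exact half-lives of compounds 1, 2, 3 and 4 are, and whether the groups on the sulfonyl sulfur separate them at all in this assay.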